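A few compounds are considered here, and "the series" means these few. Any claim that something is new, unique, unknown or untested is made for them only; others in the source may bear on it.

Three related compounds have numbers in a functional assay on the whole organism with Rattus norvegicus as the target, at a dose of 25 mg/kg by the intravenous route; on this read-out lower numbers stand for an effect already at smaller amounts and higher numbers for an effect only at larger amounts of compound. In that test, compound 1 (`O=C(O)c1cc(NC(=O)c2ccc(-c3nn[nH]n3)cc2)cc(C(=O)O)c1`) gives 1.2 mg/kg. Compound 2 (`O=C(Nc1ccccc1-c1nn[nH]n1)c1ccc(-c2nn[nH]n2)cc1`) gives 1.5 mg/kg, which lies within the usual scatter of the number for compound 1, so these two cannot be told apart. Compound 3 (`N#Cc1cccc(C(=O)Nc2cc(C(=O)O)cc(C(=O)O)c2)c1`) gives 5 mg/kg, and its gap to compound 1 lies beyond the scatter. Compound 1 therefore stands at the low end of the three numbers, level with compound 2.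

Compound 4 (`N#Cc1ccc(C(=O)Nc2cc(C(=O)O)cc(C(=O)O)c2)cc1`) has not yet been measured. It differs from compound 1 in one place, with cyano in place of 2H-tetrazol-5-yl on an aromatic carbon. Among the compounds with values here, no two measured compounds differ in only one place, so no direct step shows what this swap does. The nearest guide is compound 3, which also carries cyano and gives 5 mg/kg. A move toward a higher number is therefore expected, meaning that a larger dose would be needed, and this move probably lies beyond the scatter. The estimated step is a 3.3-fold higher number from compound 1 to compound 4 (0.52 log units; beyond the scatter). For compound 4 the estimated value is 4 mg/kg, with an expected range from 1.5 mg/kg to 11 mg/kg.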

Compound 4, dose for 50% inhibition: 1.7 mg/kg
For compound 4 the middle estimate is 2.4-fold (0.37 log units) above the measured one; measured number inside the range.
By their numbers in this assay, from the lowest: compounds 1, 2 and 4 (each within the scatter of the next); then compound 3.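

Swapping 2H-tetrazol-5-yl for cyano on an aromatic carbon, para to a large group, gives in this assay a first direct reading for this position (a 1.4-fold higher number from compound 1 to compound 4 (0.15 log units; within the scatter)), so the two groups cannot be told apart here. The five-membered aromatic ring and its hydrogen-bond donor can therefore leave this place, with only 2 heavy atoms entering in place of 5, and the number stays within the scatter of that for compound 1. Compound 3 also carries cyano and gives 5 mg/kg where compound 4 gives 1.7 mg/kg, so the presence of cyano does not by itself set the number, and nothing measured here explains this outcome.

Still open, going by these compounds, is whether an amine, a carboxylic acid or a longer chain at this same place would also stay within the scatter of compound 1. Also open, on these data alone, is whether cyano would give a similar result on the core of compound 2, which carries 2H-tetrazol-5-yl as well but lacks the two carboxylic acid groups of compound 1.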